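A second chloro on the core of compound 1

The source may report more compounds than this note shows. Statements on the series, on what has been measured and on what is new or still open speak of the compounds shown alone.

Compound 1 `ClCc1ccccc1Cn1cnc2ncnc(Cl)c21` gives 85100 nM in a functional assay on SK-OV-3 cells (Homo sapiens) for cytotoxicity, read by sulforhodamine B assay, with a stated time of 48 h; on this read-out higher numbers stand for lower toxicity in this test and lower numbers for higher toxicity in this test. Compound 2 `ClCc1ccc(Cn2cnc3c(Cl)nc(Cl)nc32)cc1` gives 66100 nM in this assay. Compound 3 `Nc1nc(Cl)c2ncn(Cc3cccc(CCl)c3)c2n1` reaches only the limit of > 100000 nM in this assay, so for it no number is known.

Of the two numbers shown, compound 1 gives the highest, with compound 2 the nearest, and the gap from compound 1 to compound 2 lies within the scatter, so no order can be read from these two. Compound 3 sits at the limit of > 100000 nM in this assay, at which 1 of the 3 values shown sits, and contributes no number at all.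

Compound 4 `ClCc1ccccc1Cn1cnc2nc(Cl)nc(Cl)c21` is not yet measured. It differs from compound 1 by chloro in place of hydrogen on an aromatic carbon, between two ring nitrogen atoms, meta to the existing chloro group, meta to a fused ring and para to a fused ring. For the measured compounds named here, no step between two measured compounds that differ in one place is available, so the size of the change from compound 1 to compound 4 in this assay has to be guessed. Compound 2 carries the same two chloro groups on its core and gives 66100 nM, within the scatter of compound 1, so the step is expected to be small, a 1.2-fold lower number from compound 1 to compound 4 (0.08 log units; within the scatter), with no clear direction. Compound 4 is therefore estimated at 70000 nM, in the range 30000 nM to 150000 nM.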

Compound 4, concentration lethal to 50% of the cells: 56200 nM
Compound 4: the middle estimate sits 1.2-fold (0.10 log units) above what was measured, and the stated range covers the measured number.
By their numbers in this assay, from the lowest: compounds 4, 2 and 1 (each within the scatter of the next). At a limit, above all of these: compound 3.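

For the compounds shown here, the swap of hydrogen for chloro on an aromatic carbon, between two ring nitrogen atoms, gives the first step that can be read on the core of compound 1: in this assay it is a 1.5-fold lower number from compound 1 to compound 4 (0.18 log units; within the scatter) and cannot be told apart from repeat measurements. Going by these compounds alone, this position therefore carries a second chloro without a difference that this read-out can resolve, which the earlier compounds, differing from one another in more than one place, could not show. Nothing measured here offers a reason for this result.

From the compounds shown here alone, whether any other group at this position would give a step beyond the scatter stays open, for example an amine, a methoxy group or a longer chain. A carboxylic acid at the same place is equally untested among the compounds shown.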